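Substituent changes on the ring amide nitrogen

This account rests on a few compounds, and the source may have more. Where it says the series, first, only, none or still open, it means among the compounds named here.

Measured so far in a functional assay, with a stated time of 20 min, tested at 3 mg/mL; on this read-out higher numbers stand for a stronger effect at the one concentration tested and lower numbers for a weaker effect:
compound 1 `CC(C)[C@@H]1CC[C@@H](C)C[C@@]12N(C)C(=O)[C@@H]1[C@H]3C(=O)NC(=O)[C@H]3ON12` gives 80.3%
compound 2 `CC(C)[C@@H]1CC[C@@H](C)C[C@@]12N(C)C(=O)[C@@H]1[C@H]3C(=O)N(C)C(=O)[C@H]3ON12` gives 64%

Within the data shown here, compound 2 has the lower of the two numbers; the one step known, a number 16.3 percentage points lower from compound 1 to compound 2 (beyond the scatter), is modest and downward. Compound 3 `Cc1cccc(N2C(=O)[C@H]3[C@H](ON4[C@@H]3C(=O)N(C)[C@@]43C[C@H](C)CC[C@H]3C(C)C)C2=O)c1` carries a further change at the same nitrogen: 3-methylphenyl in place of methyl on an amide-type nitrogen in a ring. Among the measured compounds shown here, no measured step covers this exchange, so the methyl-for-hydrogen step is the only guide, and it does not reach far. Compound 3 is therefore expected to move little in this assay, if at all, with a number 9 percentage points lower from compound 2 to compound 3 (within the scatter). The estimate for compound 3 is 55%, between 25% and 80%.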

Compound 3, a percentage reported as activity, at one concentration (the size of the read-out at that concentration, not a potency): 73.8%
Estimate against measurement, compound 3: 18.8 percentage points below, and the stated range covers the measured number.
By their numbers in this assay, from the lowest: compounds 2, 3 and 1 (each within the scatter of the next, the first and the last beyond it).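

The ring amide nitrogen accepts 3-methylphenyl in this assay: replacing methyl gives a number 9.8 percentage points higher from compound 2 to compound 3 (within the scatter), and replacing the amide hydrogen gives a number 6.5 percentage points lower from compound 1 to compound 3 (within the scatter). The loss seen with methyl therefore does not carry over to every substituent on this nitrogen, and the number does not follow substituent size across compounds 1, 2 and 3. No available evidence bears on this result.

As far as these compounds go, it remains open how an unsubstituted phenyl, a benzyl or a longer alkyl chain on this nitrogen would read. These single-concentration numbers also leave potency unresolved.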